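The compounds below may be only part of what the source reports. "The series", "measured", "known", "first", "only" and "open" are said of these compounds alone.

Working notes on the series. Among the compounds with values here, in a functional assay on HepG2 cells (Homo sapiens) for antiproliferative activity, read by MTT assay, with a stated time of 48 h (a higher number here means a weaker inhibitor, a lower number a stronger inhibitor), three compounds sharing one core have numbers so far. Compound 1 (`O=C(Nc1ccc(Cl)cc1)Nc1cccc(CNc2nccnc2Cl)c1`) gives 8350 nM, compound 2 (`Cc1cccc(NC(=O)Nc2cccc(CNc3nccnc3Cl)c2)c1`) gives 11200 nM, and compound 3 (`O=C(Nc1cccc(CNc2nccnc2Cl)c1)Nc1ccccc1F`) gives 10500 nM. Compound 3 is not separated from either of the other two, with steps of a 1.3-fold higher number from compound 1 to compound 3 (0.10 log units; within the scatter) and a 1.1-fold lower number from compound 2 to compound 3 (0.03 log units; within the scatter).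

The next compound is compound 4 (`Cc1ccc(NC(=O)Nc2cccc(CNc3nccnc3Cl)c2)cc1Cl`), which carries 3-chloro-4-methylphenyl in place of 2-fluorophenyl on an amide-type nitrogen.

All three measured steps are exchanges on that same nitrogen, so all bear on this change. The third is a 1.3-fold higher number from compound 1 to compound 2 (0.13 log units; within the scatter). Swapping the group at this place has so far not moved the number beyond the scatter in this assay, across the three groups tried. No measured compound carries both a chlorine and a methyl on this ring, so the combination itself remains untested, and the range is kept wide for that reason.

No step beyond the scatter is expected, and the direction is not firmly indicated. The estimated step is small: a 1.2-fold lower number from compound 3 to compound 4 (0.07 log units; within the scatter). For compound 4 the estimated value is 9000 nM, with an expected range of 4000 nM to 18000 nM.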

Compound 4, half-maximal inhibitory concentration: 11300 nM
The estimate for compound 4 lay 1.3-fold (0.10 log units) below the measured number; measured number inside the range.
By their numbers in this assay, from the lowest: compounds 1, 3, 2 and 4 (each within the scatter of the next).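

In this assay, the combination of a chlorine and a methyl on one ring, untested until now, stays within the scatter of every other group tried on this amide-type nitrogen: a 1.1-fold higher number from compound 3 to compound 4 (0.03 log units; within the scatter), a 1.0-fold higher number from compound 2 to compound 4 (0.00 log units; within the scatter) and a 1.4-fold higher number from compound 1 to compound 4 (0.13 log units; within the scatter) are all printed as within it. Within the data shown here, the four substituted phenyl groups on this nitrogen therefore cannot be told apart in this assay, and 3-chloro-4-methylphenyl, with its 8 heavy atoms against 7 for 2-fluorophenyl, gives no separation from the earlier compounds. Nothing measured here bears on why these four values cannot be separated.

Going by these compounds, all four compounds keep the shared core and carry on this nitrogen only a phenyl group with chlorine, fluorine or methyl, so it remains open whether an amine or a carboxylic acid on that ring, or a longer alkyl chain in place of the ring, would give a step beyond the scatter. Also open is whether this position stays as unresponsive when the rest of the core is altered, since every compound shown has the same remainder.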